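Saturated ring replaces aryl on the amine nitrogen

A few compounds are considered here, and "the series" means these few. Any claim that something is new, unique, unknown or untested is made for them only; others in the source may bear on it.

For the measured compounds named here, compound 3 `Cc1ccc(S(=O)(=O)/N=C(/CCNC2=CC(=O)c3ccccc3C2=O)Nc2cc(F)c(F)c(F)c2)cc1` gives 8580 nM in a functional assay on HeLa cells (Homo sapiens) for cytotoxicity, read by MTT assay, with a stated time of 48 h (on this read-out higher numbers stand for weaker inhibition and lower numbers for stronger inhibition), the lowest of the three numbers so far. Compound 1 `Cc1ccc(S(=O)(=O)/N=C(/CCNC2=CC(=O)c3ccccc3C2=O)Nc2ccc(Cl)cc2)cc1` gives 13400 nM and compound 2 `COc1ccc(N/C(CCNC2=CC(=O)c3ccccc3C2=O)=N\S(=O)(=O)c2ccc(C)cc2)cc1OC` gives 14500 nM; the steps of a 1.6-fold lower number from compound 1 to compound 3 (0.19 log units; within the scatter) and a 1.7-fold lower number from compound 2 to compound 3 (0.23 log units; within the scatter) both lie within the scatter, as does a 1.1-fold higher number from compound 1 to compound 2 (0.03 log units; within the scatter), so no order among the three can be claimed. Compound 4 `Cc1ccc(S(=O)(=O)/N=C(/CCNC2=CC(=O)c3ccccc3C2=O)NC2CCCCC2)cc1` differs from compound 3 by cyclohexyl in place of 3,4,5-trifluorophenyl on an amine nitrogen. Going by the values given here, every measured step exchanges one aromatic ring for another on that nitrogen; none exchanges it for a non-aromatic ring, so the present change has no direct precedent here. Since the three aryl swaps all stayed within the scatter, no step beyond the scatter in this assay is expected for a 1.4-fold higher number from compound 3 to compound 4 (0.15 log units; within the scatter), though the range is kept wide for the untested ring type. Compound 4 is expected at 12000 nM, with a range from 4000 nM to 36000 nM.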

Compound 4, half-maximal inhibitory concentration: 9770 nM
Beside the measured number, compound 4's estimate is 1.2-fold (0.09 log units) above it, and the stated range covers the measured number.
By their numbers in this assay, from the lowest: compounds 3, 4, 1 and 2 (each within the scatter of the next).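

In this assay, the first non-aromatic ring on this amine nitrogen leaves the numbers where the aryl groups had them: a 1.1-fold higher number from compound 3 to compound 4 (0.06 log units; within the scatter) and a 1.5-fold lower number from compound 2 to compound 4 (0.17 log units; within the scatter) and a 1.4-fold lower number from compound 1 to compound 4 (0.14 log units; within the scatter) all lie within the scatter. Across these four compounds, an aromatic ring on this nitrogen is therefore not required for a number in this range, and cyclohexyl is tolerated as well as the three aryl groups. No supporting data bear on why this position responds so little to the change.

On these data alone, whether any ring is needed at all remains open, and a short alkyl chain or a cyclohexyl carrying an amine or a carboxylic acid would address that. Only this one position varies among the compounds shown, so the rest of the shared core remains untested here.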